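This account rests on a few compounds, and the source may have more. Where it says the series, first, only, none or still open, it means among the compounds named here.

Measured in an ADME assay on MT4 cells (Homo sapiens) for cytotoxicity, read by MTT assay; a higher number here means that more compound is tolerated, a lower number that less compound is tolerated:
- compound 1 `O=C(CSc1nncnc1-c1ccccc1Cl)Nc1ccccc1Br`: 73000 nM
- compound 2 `O=C(CSc1nncnc1-c1ccccc1Cl)Nc1cccnc1Cl`: 167000 nM

Within the data shown here, compound 2 holds the higher of the two numbers, and the only measured step is a 2.3-fold higher number from compound 1 to compound 2 (0.36 log units; beyond the scatter). Compound 3 `O=C(CSc1nncnc1-c1ccccc1Cl)Nc1ccccc1[N+](=O)[O-]` carries 2-nitrophenyl in place of 2-chloropyridin-3-yl on an amide-type nitrogen, which brings back a six-membered aromatic ring of carbon only, as the 2-bromophenyl of compound 1 has. The measured step therefore bears on this change, and a modest step of similar size in the opposite direction is expected. The expected step is a 2.1-fold lower number from compound 2 to compound 3 (0.32 log units; beyond the scatter). For compound 3 the estimate is 80000 nM, with an expected range of 35000 nM to 180000 nM.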

Compound 3, half-maximal cytotoxic concentration: 63000 nM
Compound 3: the middle estimate sits 1.3-fold (0.10 log units) above what was measured; the range from low to high includes it.
By their numbers in this assay, from the lowest: compounds 3 and 1 (each within the scatter of the next); then compound 2.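

In this assay there is a 2.7-fold lower number from compound 2 to compound 3 (0.42 log units; beyond the scatter), so compound 2 now stands apart from two carbon-only aromatic rings on the amide-type nitrogen, not just one. Nitro in place of bromo on an aromatic carbon gives a 1.2-fold lower number from compound 1 to compound 3 (0.06 log units; within the scatter), so this assay does not tell those two groups apart. Nothing shown here explains these differences. Still open, on these data alone, is whether the ring nitrogen or the chlorine of compound 2 accounts for its separation from the others, a question a 2-chlorophenyl group at this place would address. As far as these compounds go, how an amine on the phenyl ring would compare also remains open.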